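A few compounds are considered here, and "the series" means these few. Any claim that something is new, unique, unknown or untested is made for them only; others in the source may bear on it.

Of the compounds shown here, three built on one shared core have been measured in an in vivo ADME assay on the whole organism (plasma, strain Sprague-Dawley) for pharmacokinetics, with Rattus norvegicus as the target, at a dose of 1 mg/kg by the intravenous route; a lower number here means slower removal, a higher number faster removal of the compound. Compound 1 `COc1cc(C(=O)N2[C@@H](c3nccs3)[C@@H](C(N)=O)C[C@@]2(CC(C)C)C(=O)O)ccc1C(C)(C)C` gives 37 mL/min/kg, compound 2 `CC(C)C[C@@]1(C(=O)O)C[C@H](C(N)=O)[C@H](c2nccs2)N1C(=O)c1ccc(C(C)(C)C)c(Cl)c1` gives 29 mL/min/kg, and compound 3 `CC(C)C[C@@]1(C(=O)O)C[C@H](C(N)=O)[C@H](c2nccs2)N1C(=O)c1ccc(C(C)(C)C)cc1` gives 21 mL/min/kg. These three numbers all lie within the usual scatter of one another, so compound 3 cannot truly be ranked against either of the others.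

Compound 4 `CC(C)C[C@@]1(C(=O)O)C[C@H](C(N)=O)[C@H](c2nccs2)N1C(=O)c1ccc(C(C)(C)C)c(Br)c1` differs from compound 3 in one place: bromo in place of hydrogen on an aromatic carbon. This is bromo in place of hydrogen on an aromatic carbon, ortho to a tert-butyl group.

Among the measured compounds shown here, no bromo compound has been measured yet, so the guidance comes from related swaps on the same aromatic ring. The closest is the chloro compound, where putting hydrogen in place of chloro gave a 1.4-fold lower number from compound 2 to compound 3 (0.14 log units; within the scatter). Putting hydrogen in place of methoxy gave a 1.8-fold lower number from compound 1 to compound 3 (0.25 log units; within the scatter). Both steps are small enough to stay within the scatter, so no step beyond the scatter is expected in this assay, and no firm direction can be claimed.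

The estimated step is a 1.3-fold higher number from compound 3 to compound 4 (0.12 log units; within the scatter), a shift that would not stand out from the scatter. Compound 4 is expected to give about 28 mL/min/kg, with an estimated range of 16 mL/min/kg to 48 mL/min/kg.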

Compound 4, clearance: 24 mL/min/kg
The estimate for compound 4 lay 1.2-fold (0.07 log units) above the measured number; measured number inside the range.
By their numbers in this assay, from the lowest: compounds 3, 4, 2 and 1 (each within the scatter of the next).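

In this assay, the new bromo compound gives a 1.1-fold higher number from compound 3 to compound 4 (0.06 log units; within the scatter), and swapping the other groups on the same aromatic carbon, ortho to a tert-butyl group, gives a 1.2-fold lower number from compound 2 to compound 4 (0.08 log units; within the scatter) and a 1.5-fold lower number from compound 1 to compound 4 (0.19 log units; within the scatter). With bromo added, this position has now carried hydrogen, chloro, bromo and methoxy, and none of the steps among these four compounds rises above the scatter, so replacing hydrogen here with a single bromine atom leaves clearance in rats indistinguishable from that of compound 3. Nothing available explains the small differences between these compounds or shows what happens to the bromo compound in the body.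

The compounds shown leave open whether a very different group on this aromatic carbon, such as an amine, a carboxylic acid or a longer chain, would produce a step beyond the scatter. As far as these compounds go, all four compounds also keep the tert-butyl group, so it remains open whether these swaps would stay as small if a trifluoromethyl group stood in its place.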